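Amine-to-aldehyde swap checked for cytotoxicity in skin cells

This account rests on a few compounds, and the source may have more. Where it says the series, first, only, none or still open, it means among the compounds named here.

Compound 1 `CCOC(=O)CCCCCOc1cccc(CNC(C)C)c1` in an ADME assay on BJ cells (Homo sapiens) for cytotoxicity, read by CellTiter-Glo and resazurin assay, with a stated time of 72 h; a lower number here means that less compound is needed, a higher number that more compound is needed for the effect: > 26000 nM, a limit of the assay.
Compound 2 `CCCNCc1cccc(OCCCCCC(=O)OCC)c1` in this assay: > 26000 nM, a limit of the assay.

In this assay compound 2 stands only at a limit, > 26000 nM. The step that the two limits leave unreadable from compound 1 to compound 2 cannot be sized, since (the limit of > 26000 nM in this assay, at which 2 of the 2 values shown sit). Compound 3 `CCOC(=O)CCCCCOc1cccc(C=O)c1` differs from compound 2 by formyl in place of (propylamino)methyl on an aromatic carbon. Among the compounds with values here, no measured step covers this exchange, and the one measured step gives no readable size. With compound 2 at the limit, the step that the limit leaves unreadable from compound 2 to compound 3 is expected to stay within the scatter, and compound 3 is expected again to sit at the limit. The estimate for compound 3 is 30000 nM, with a range from 8000 nM to 100000 nM.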

Compound 3, half-maximal effective concentration: > 26000 nM
Compound 3: a limit, no number (the forecaster's own chance of this, stated with the estimate: 70%); the middle value is on the limit's open side.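

No step from compound 1 or compound 2 to compound 3 can be read, because all three stand only at a limit: the limit of > 26000 nM in this assay, at which 3 of the 3 values shown sit.

The compounds shown leave open whether formyl in place of (propylamino)methyl changes the result in this assay at all.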